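The compounds below may be only part of what the source reports. "The series", "measured", "known", "first", "only" and "open" are said of these compounds alone.

Measured compounds: compound 1, `CC1=C(C(=O)C2CC2)C(c2ccsc2)NC(=O)N1`, gives 1% in an assay on membranes from HEK293 cells for displacement of a labelled ligand from adenosine receptor A2b (Homo sapiens), read by scintillation counting, with a stated time of 30 min, tested at 1 uM; a lower number here means less inhibition, a higher number more inhibition at the concentration tested (going by the name of the read-out); compound 2, `CC1=C(C(=O)SC(C)C)C(c2ccsc2)NC(=O)N1`, gives 14% in this assay.

Within the data shown here, compound 2 holds the higher of the two numbers measured so far, the step of a number 13 percentage points higher from compound 1 to compound 2 (beyond the scatter) being beyond the scatter yet modest in size. Among the measured compounds shown here, the only measured step is this one, and it concerns the same carbonyl carbon that is changed next.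

Compound 3, `CCC(CC)OC(=O)C1=C(C)NC(=O)NC1c1ccsc1`, is not yet measured. The change from compound 2 is (pentan-3-yl)oxy in place of isopropylsulfanyl on a carbonyl carbon. For the measured compounds named here, no measured pair covers this exact exchange, so only the step from compound 1 to compound 2 at the same carbonyl carbon offers any guidance, and that step was modest. The expected step in this assay is therefore small, a number 4 percentage points lower from compound 2 to compound 3 (within the scatter), with no clear direction beyond the scatter. Compound 3 is estimated to give 10%, within a range of 0% to 30%.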

Compound 3, a percentage reported as inhibition, at one concentration (the size of the read-out at that concentration, not a potency): 26%
The estimate for compound 3 lay 16 percentage points below the measured number; low and high end bracket the measured number.
By their numbers in this assay, from the lowest: compound 1; then compound 2; then compound 3.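

Replacing isopropylsulfanyl with (pentan-3-yl)oxy on the carbonyl carbon gives a number 12 percentage points higher from compound 2 to compound 3 (beyond the scatter) in this assay, so the number at this position can rise further than the level reached with isopropylsulfanyl. The full span measured at this carbon is a number 25 percentage points higher from compound 1 to compound 3 (beyond the scatter) and remains modest, with (pentan-3-yl)oxy the highest of the three groups and cyclopropyl the lowest. Nothing available accounts for this rise.

In the latest exchange, the linking atom and the carbon chain change together, so the compounds shown cannot separate their contributions. An isopropoxy group or a (pentan-3-yl)sulfanyl group on the same carbonyl carbon would separate them, while an amine there, or a longer chain on the oxygen, would show whether the number keeps rising.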